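This account rests on a few compounds, and the source may have more. Where it says the series, first, only, none or still open, it means among the compounds named here.

Within the data shown here, compound 3 `CCOC(=O)C(Sc1nc(Cl)cc(Nc2cccc(C)c2C)n1)c1ccccc1` holds the lowest of the two numbers so far in an assay for inhibition of Polyunsaturated fatty acid 5-lipoxygenase (Homo sapiens), tested at 1 uM (on this read-out lower numbers stand for a stronger effect and higher numbers for a weaker effect at the one concentration tested), giving 53.1%. Its nearest neighbour, compound 1 `CCOC(=O)CSc1nc(Cl)cc(Nc2cccc(C)c2C)n1`, gives 76.9%, and the step of a number 23.8 percentage points lower from compound 1 to compound 3 (beyond the scatter) was beyond the scatter though modest. Compound 2 `CCOC(=O)C(C)Sc1nc(Cl)cc(Nc2cccc(C)c2C)n1` is reported in this assay as "not active" (no number reported), with no number given. Compound 4 `CCCCCCC(Sc1nc(Cl)cc(Nc2cccc(C)c2C)n1)C(=O)OCC` differs from compound 3 by hexyl in place of phenyl on a saturated chain carbon bound to a carbonyl carbon and a sulfur. Among the measured compounds shown here, no measured step exchanges phenyl for hexyl at that carbon, so only the modest gain seen on adding phenyl bears on it, and part of that gain is expected to be lost. Compound 4 is therefore estimated at 68%, within 42% to 94%. This estimate means an expected step of a number 14.9 percentage points higher from compound 3 to compound 4 (beyond the scatter).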

Compound 4, a percentage reported as activity, at one concentration (the size of the read-out at that concentration, not a potency): 84.9%
The estimate for compound 4 lay 16.9 percentage points below the measured number; the measured number falls inside the stated range.
By their numbers in this assay, from the lowest: compound 3; then compounds 1 and 4 (each within the scatter of the next).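

At the saturated chain carbon bound to a carbonyl carbon and a sulfur, the effect of phenyl does not carry over to hexyl, an open chain with no ring: the exchange gives a number 31.8 percentage points higher from compound 3 to compound 4 (beyond the scatter). Set against hydrogen, hexyl gives a number 8 percentage points higher from compound 1 to compound 4 (within the scatter), so of the two groups only phenyl stands apart from hydrogen at this carbon. Nothing available explains this difference. The compounds shown leave open whether a ring as such is enough, and how cyclohexyl or benzyl at this carbon would compare with phenyl.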